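A few compounds are considered here, and "the series" means these few. Any claim that something is new, unique, unknown or untested is made for them only; others in the source may bear on it.

Measured so far in an ADME assay on a cell-free system (plasma, Rattus norvegicus) for protein binding, for two compounds:
- compound 1 `CNc1nccc(N2CC[C@H](NC(=O)Nc3ccc(Cl)c(C(F)(F)F)c3)C2)n1` gives 99.7% here
- compound 2 `O=C(Nc1ccc(Cl)c(C(F)(F)F)c1)N[C@H]1CCN(c2ccncn2)C1` gives 99.4% here

For the measured compounds named here, compound 1 stands within the scatter of compound 2, the only measured step being a 2.0-fold higher unbound fraction from compound 1 to compound 2 (0.30 log units; within the scatter), with hydrogen in place of methylamino. That step concerns another place, so it offers no direct guide to compound 3 `CNc1nccc(N2CC[C@H](NC(=O)Nc3ccc(CN4CCN(C)CC4)c(C(F)(F)F)c3)C2)n1`, which differs from compound 1 by (4-methylpiperazin-1-yl)methyl in place of chloro on an aromatic carbon, with (4-methylpiperazin-1-yl)methyl in place of chloro. Going by the values given here, no measured step covers this change, so the expectation is tentative: a step beyond the scatter towards more unbound compound. For compound 3 the estimate is 97.5%, with an expected range from 93% to 99.4% here. This expected value would mean an 8.3-fold higher unbound fraction from compound 1 to compound 3 (0.92 log units; beyond the scatter) overall.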

Compound 3, plasma protein binding: 85.1%
The estimate for compound 3 lay 6.0-fold (0.78 log units) (unbound fraction) below the measured number; measured number outside the range, below it.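

Replacing chloro with (4-methylpiperazin-1-yl)methyl on the aromatic carbon ortho to a trifluoromethyl group gives a 50-fold higher unbound fraction from compound 1 to compound 3 (1.70 log units; beyond the scatter) in this assay, so this position can carry a large step. The earlier compounds shown here showed only a step within the scatter, at another place. No measurement shown here accounts for this step.

Going by these compounds, it remains open which part of the entering group goes with the step, and whether a morpholin-4-ylmethyl or dimethylaminomethyl group here would give a similar one. On these data alone, whether the same replacement on compound 2 would give a similar step also remains open.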